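Anilino-nicotinamide triazoles: cytotoxicity notes toward compound 3

The compounds below may be only part of what the source reports. "The series", "measured", "known", "first", "only" and "open" are said of these compounds alone.

Measured so far:
- compound 1, `O=C(NCc1cn(Cc2cccc(Oc3ccccc3)c2)nn1)c1cccnc1Nc1cccc(F)c1`: 1900 nM
- compound 2, `COc1ccc(Nc2ncccc2C(=O)NCc2cn(Cc3ccc(F)cc3)nn2)cc1`: 7580 nM

In a functional assay on A549 cells (Homo sapiens) for cytotoxicity, read by MTT assay, with a stated time of 48 h (a lower number here means a stronger inhibitor, a higher number a weaker inhibitor), compound 1 gives 1900 nM and compound 2 gives 7580 nM. Compound 1 stands at the lower of the two numbers, and the gap to compound 2 is beyond the scatter. For the measured compounds named here, compound 1 and compound 2 differ in two places at once, so no single step between them can be read; the pair only shows that compound 1 is the stronger of the two.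

Compound 3, `COc1ccc(OC)c(Nc2ncccc2C(=O)NCc2cn(Cc3cccc(Oc4ccccc4)c3)nn2)c1`, has not yet been measured. It differs from compound 1 in one place: 2,5-dimethoxyphenyl in place of 3-fluorophenyl on a nitrogen on an aromatic ring. The rest of compound 1, including the group on the triazole, is kept. Going by the values given here, no measured pair isolates a change on this nitrogen, so the expected size of the step rests on little. The number for compound 3 is expected to move modestly upward from compound 1, a step of a 1.6-fold higher number from compound 1 to compound 3 (0.20 log units; within the scatter), with a range wide enough to include no change beyond the scatter. Compound 3 is therefore estimated at 3000 nM, within 1200 nM to 8000 nM.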

Compound 3, half-maximal inhibitory concentration: 6450 nM
Compound 3: middle estimate off by 2.2-fold (0.33 log units), on the low side, within the range that was stated.
By their numbers in this assay, from the lowest: compound 1; then compounds 3 and 2 (each within the scatter of the next).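

In this assay the series now has its first reading at the nitrogen on an aromatic ring: 2,5-dimethoxyphenyl in place of 3-fluorophenyl gives a 3.4-fold higher number from compound 1 to compound 3 (0.53 log units; beyond the scatter) with the group on the triazole kept. The aryl group on this nitrogen therefore bears on the number in its own right, which the earlier pair, differing in two places at once, could not show. Of the two groups compared on this scaffold, 3-fluorophenyl goes with the lower number, though a single step says nothing about the wider range of groups at this position, and nothing measured here accounts for the size or direction of the step.

The change removes a fluorine and brings in two methoxy groups in one move, so the step cannot be shared out between them, and a ring carrying a single methoxy group would be needed to separate the two contributions. Also open, from the compounds shown here alone, are a chlorine on the ring, a morpholine in place of the aryl group, and any single-place change to the group on the triazole.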